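Compound 3 and the amide aryl group

The source may hold more compounds than are shown below. What is called first, only, known or untested is meant among the compounds shown, and "the series" means these compounds.

Measured in a functional assay on HT-29 cells (Homo sapiens) for cytotoxicity, read by MTT assay, with a stated time of 72 h (on this read-out lower numbers stand for stronger inhibition and higher numbers for weaker inhibition), with one compound still open:
- compound 1 `O=C(CN1CCN(c2nnc(Cc3ccccc3)c3ccccc23)CC1)Nc1ccc(F)c(C(F)(F)F)c1` gives 4590 nM
- compound 2 `O=C(CN1CCN(c2nnc(Cc3ccccc3)c3ccccc23)CC1)Nc1cc(C(F)(F)F)ccc1Cl` gives 66800 nM
- compound 3 `O=C(CN1CCN(c2nnc(Cc3ccccc3)c3ccccc23)CC1)Nc1cccc(F)c1` has no value yet

Compound 2 stands highest of the two numbers, and so is the weaker of the pair in this assay. Within the data shown here, its nearest neighbour is compound 1, and only one measured step bears on what follows: a 15-fold higher number from compound 1 to compound 2 (1.16 log units; beyond the scatter). That step is large. Compound 1 and compound 2 differ only in the group on the amide-type nitrogen.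

The next change falls at the same place: 3-fluorophenyl in place of 2-chloro-5-(trifluoromethyl)phenyl on an amide-type nitrogen. In words, 3-fluorophenyl enters in place of 2-chloro-5-(trifluoromethyl)phenyl on an amide-type nitrogen. Like compound 1 (4590 nM), compound 3 carries a fluorine on this ring and no chlorine, which points towards the lower number, although a single step gives thin support. The expected move is a 4.8-fold lower number from compound 2 to compound 3 (0.68 log units; beyond the scatter), a clear fall but probably not all the way back. For compound 3 the estimated value is 14000 nM, with an expected range from 4000 nM to 50000 nM.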

Compound 3, half-maximal inhibitory concentration: 95000 nM
Estimate against measurement, compound 3: 6.8-fold (0.83 log units) below; measured number outside the range, above it.
By their numbers in this assay, from the lowest: compound 1; then compounds 2 and 3 (each within the scatter of the next).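

In this assay, the step of a 1.4-fold higher number from compound 2 to compound 3 (0.15 log units; within the scatter) shows that compound 2 and compound 3 cannot be told apart, even though the 2-chloro-5-(trifluoromethyl)phenyl group and the smaller 3-fluorophenyl group differ in both their chlorine and their trifluoromethyl. The other new step, a 21-fold higher number from compound 1 to compound 3 (1.32 log units; beyond the scatter), shows that a fluorine on this ring does not by itself bring the lower number: of the three aryl groups on the amide-type nitrogen, only the 4-fluoro-3-(trifluoromethyl)phenyl of compound 1 stands apart, while compound 2 carries trifluoromethyl without fluorine and compound 3 carries fluorine without trifluoromethyl. No measurement here bears on why this aryl group gives such a different result at this position.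

From the compounds shown here alone, with three compounds, it remains open whether the number of compound 1 depends on fluorine and trifluoromethyl together or on the particular arrangement of these groups on the ring. Also open, going by these compounds, is how this position would respond to a plain phenyl ring, a phenyl ring bearing only trifluoromethyl, or a ring carrying a methoxy group or a nitrile.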